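Trifluoromethyl in Place of Chloro on the Aromatic Ring

A few compounds are considered here, and "the series" means these few. Any claim that something is new, unique, unknown or untested is made for them only; others in the source may bear on it.

Compound 3 `CCN1C(=O)CC[C@H]1C(=O)NCc1cccc(Cl)c1` stands on a limit rather than a number: in an assay on isolated protein for inhibition of P2X purinoceptor 7 (Homo sapiens) (a lower number here means a stronger inhibitor, a higher number a weaker inhibitor), compound 3 gives < 1000 nM, which is a limit of the assay. Compound 2 `CCN1C(=O)CC[C@H]1C(=O)NCc1ccccc1` stands the same way: in this assay compound 2 gives < 1000 nM, again a limit. Among the compounds with values here, the only measured step touching this pair, a step that the two limits leave unreadable from compound 2 to compound 3, is therefore unreadable, as the limit of < 1000 nM in this assay, at which 2 of the 3 values shown sit, shows. Within the data shown here, compound 1 `O=C(NCc1ccc(F)cc1Cl)[C@@H]1CCC(=O)N1C1CCC1` differs from compound 3 at the lactam nitrogen and on the aromatic ring at once; in this assay compound 1 gives 25.1 nM, and no step to it is available.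

Compound 4 `CCN1C(=O)CC[C@H]1C(=O)NCc1cccc(C(F)(F)F)c1` differs from compound 3 in one place: trifluoromethyl in place of chloro on an aromatic carbon. No readable step bears on this change, so the expectation rests on the limit of compound 3 alone. The step that the limit leaves unreadable from compound 3 to compound 4 is expected to stay within the scatter. Compound 4 is thus estimated at 300 nM in this assay, with a range from 40 nM to 1500 nM.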

Compound 4, half-maximal inhibitory concentration: 100 nM
Estimate against measurement, compound 4: 3.0-fold (0.48 log units) above; the range from low to high includes it.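

The steps from compound 2 and from compound 3 to compound 4 cannot be read, because compound 2 and compound 3 both stand on a limit: the limit of < 1000 nM in this assay, at which 2 of the 4 values shown sit. The compounds shown leave open how hydrogen, chloro and trifluoromethyl on the aromatic ring actually compare in this assay.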